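Replacing trifluoromethyl with nitro on the shared core

The source may report more compounds than this note shows. Statements on the series, on what has been measured and on what is new or still open speak of the compounds shown alone.

In a functional assay on NALM-6 cells (Homo sapiens) for cytotoxicity, read by luminescence and CellTiter-Glo, with a stated time of 3 days (on this read-out higher numbers stand for weaker inhibition and lower numbers for stronger inhibition), compound 1 (`O=C(Nc1ccc(OC(F)(F)F)cc1)c1cc(F)ccc1O`) gives 1210 nM and compound 2 (`O=C(Nc1ccc(C(F)(F)F)cc1)c1cc(F)ccc1O`) gives 2090 nM. These two values lie within the usual scatter of each other, so compound 2 stands level with compound 1 and the pair cannot be ranked. The next compound, compound 3 (`O=C(Nc1ccc([N+](=O)[O-])cc1)c1cc(F)ccc1O`), has nitro in place of trifluoromethyl on an aromatic carbon of compound 2: nitro in place of trifluoromethyl on an aromatic carbon. For the measured compounds named here, only one measured step bears on this change, a swap of trifluoromethyl for trifluoromethoxy on an aromatic carbon: a 1.7-fold higher number from compound 1 to compound 2 (0.24 log units; within the scatter). Going by the values given here, that step stayed within the scatter, but it is a single step, and no nitro compound has a measured value yet. The expected step is a 1.0-fold lower number from compound 2 to compound 3 (0.02 log units; within the scatter), with no change beyond the scatter expected. For compound 3 the estimate is 2000 nM, with an expected range from 700 nM to 6000 nM.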

Compound 3, half-maximal inhibitory concentration: 2080 nM
Compound 3: middle estimate off by 1.0-fold (0.02 log units), on the low side; measured number inside the range.
By their numbers in this assay, from the lowest: compounds 1, 3 and 2 (each within the scatter of the next).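

In this assay putting nitro in place of trifluoromethyl gives a 1.0-fold lower number from compound 2 to compound 3 (0.00 log units; within the scatter) and putting nitro in place of trifluoromethoxy gives a 1.7-fold higher number from compound 1 to compound 3 (0.24 log units; within the scatter) and both steps stay within the scatter. At this aromatic carbon, para to a large group, three groups now stand level, even though nitro carries no fluorine and brings 2 hydrogen-bond acceptors where trifluoromethyl has 0. No measurement shown here explains why these compounds read alike.

As far as these compounds go, whether an amine, a carboxylic acid or a longer chain at this same carbon would also stand level with compounds 1, 2 and 3 remains open. Also open, from the compounds shown here alone, is whether a chlorine atom in place of the fluorine elsewhere on the shared core would leave the reading level.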